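A few compounds are considered here, and "the series" means these few. Any claim that something is new, unique, unknown or untested is made for them only; others in the source may bear on it.

Series values in a functional assay on HCT-116 cells (Homo sapiens) for inhibition, read by colorimetric assay, with a stated time of 3 days; on this read-out lower numbers stand for stronger inhibition and higher numbers for weaker inhibition:

Compound 1 `CCOc1ccc(-c2cnc(NC(=O)CCCCCCNC(=O)C(O)(O)C(F)(F)F)s2)cc1`: compound 1 gives 4050 nM.
Compound 2 `O=C(CCCCCCNC(=O)C(O)(O)C(F)(F)F)Nc1nc2ccccc2o1`: compound 2 gives 3450 nM.
Compound 3 `OC(O)(c1c(F)c(F)c(-n2cc(-c3ccccc3)nn2)c(F)c1F)C(F)(F)F`: compound 3 gives > 100000 nM, which is a limit of the assay and not a number.

Compound 2 at 3450 nM lies within the scatter of compound 1 at 4050 nM, so the two numbers in the series cannot be ranked. Compound 2 therefore stands level with compound 1.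

The next compound to read is compound 4 `CC(=O)c1ccc(NC(=O)CCCCCCNC(=O)C(O)(O)C(F)(F)F)cc1`. It carries 4-acetylphenyl in place of 1,3-benzoxazol-2-yl on an amide-type nitrogen.

Among the compounds with values here, no step between measured compounds that differ in one place is available to size this change directly. Within the data shown here, the only guide is that compound 1 at 4050 nM and compound 2 at 3450 nM carry different groups at this end and still fall within the scatter of each other. On that basis, no step beyond the scatter is expected in this assay. The estimated change is a 1.1-fold higher number from compound 2 to compound 4 (0.04 log units; within the scatter). For compound 4 the expected value is 3800 nM. The estimated range for compound 4 runs from 1400 nM to 10000 nM.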

Compound 4, half-maximal inhibitory concentration: 12100 nM
Compound 4: middle estimate off by 3.2-fold (0.50 log units), on the low side; measured number outside the range, above it.
By their numbers in this assay, from the lowest: compounds 2 and 1 (each within the scatter of the next); then compound 4. At a limit, above all of these: compound 3.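

In this assay, within the data shown here, the group on the amide-type nitrogen is not silent: 4-acetylphenyl in place of 1,3-benzoxazol-2-yl gives a 3.5-fold higher number from compound 2 to compound 4 (0.54 log units; beyond the scatter), the first step at this position that can be read. The two groups have the same heavy-atom count, so that count does not separate them; they differ in ring make-up, with 4-acetylphenyl having one six-membered aromatic ring of carbon only and a double bond outside the ring. Nothing measured here bears on which of these differences carries the step.

On these data alone, whether the step follows from the acetyl or from the loss of the five-membered ring stays open. A plain phenyl, or a phenyl carrying an amine or a carboxylic acid in place of the acetyl, on the same nitrogen would separate the two.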